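This account rests on a few compounds, and the source may have more. Where it says the series, first, only, none or still open, it means among the compounds named here.

Of the compounds shown here, two have so far been measured in an ADME assay on the whole organism (Rattus norvegicus, strain Sprague-Dawley) for pharmacokinetics, read by LC-MS, with a stated time of 48 h, at a dose of 3 mg/kg by the intravenous route (a higher number here means more compound in the circulation at the dose given, a lower number less compound in the circulation), as maximal plasma concentration. Compound 1 (`CC#CCn1c(N2CCC[C@@H](N)C2)cc(=O)n(Cc2ccc(Cl)c(C(=O)O)c2)c1=O`) gives 59600 nM there, while compound 2 (`CC#CCn1c(N2CCC[C@@H](N)C2)cc(=O)n(Cc2ccc(F)c(C(=O)OC)c2)c1=O`) gives 2180 nM and so holds the lower of the two numbers, with a gap to compound 1 that lies beyond the usual scatter. Compound 3 (`CC#CCn1c(N2CCC[C@@H](N)C2)cc(=O)n(Cc2ccc(F)c(C(=O)O)c2)c1=O`) follows from compound 2 through a single change (hydrogen in place of methyl on an oxygen next to a carbonyl group): hydrogen in place of methyl on an oxygen next to a carbonyl group, which reads as methoxycarbonyl to carboxy. Going by the values given here, no measured pair shows this change on its own, so its size in this assay can only be judged indirectly. The judgement rests on compound 1, which also carries a carboxy group and reaches 59600 nM in that measurement. A single compound is thin support, but a rise beyond the scatter is expected, and the estimated step is an 18-fold higher number from compound 2 to compound 3 (1.26 log units; beyond the scatter) in this read-out. Compound 3 is expected at 40000 nM with an estimated range of 15000 nM to 90000 nM in this assay when it is measured.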

Compound 3, maximal plasma concentration: 63000 nM
Compound 3: the middle estimate sits 1.6-fold (0.20 log units) below what was measured; the measured number falls inside the stated range.
By their numbers in this assay, from the lowest: compound 2; then compounds 1 and 3 (each within the scatter of the next).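

The change of methoxycarbonyl to carboxy now has a measured size of its own in this assay: hydrogen in place of methyl on an oxygen next to a carbonyl group gives a 29-fold higher number from compound 2 to compound 3 (1.46 log units; beyond the scatter), a large step beyond the scatter that no single-change pair had shown before. Going by these compounds alone, the second pair tests the halogen with the carboxy group held constant: fluoro in place of chloro on an aromatic carbon gives a 1.1-fold higher number from compound 1 to compound 3 (0.02 log units; within the scatter), within the scatter, so this exchange shows no step of its own in this assay in this one pair. Nothing measured here bears on what lies behind the size of the methyl-to-hydrogen step.

The compounds shown leave open whether the halogen exchange would also show no step with methoxycarbonyl in place of carboxy, and whether the methyl-to-hydrogen step keeps its size with chloro in place of fluoro. They also leave open where an amide, a hydroxymethyl group or an ethyl ester in place of the carboxy group would stand in this assay, and whether such a compound would lie nearer compound 2 or compound 3.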